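Ester versus acid across two halogen analogues

The source may report more compounds than this note shows. Statements on the series, on what has been measured and on what is new or still open speak of the compounds shown alone.

Compound 1 `Cc1oc2ncnc(Nc3cccc(Br)c3)c2c1C(=O)O`: in a functional assay on A549 cells (Homo sapiens) for cytotoxicity, read by MTT assay, with a stated time of 72 h (a lower number here means a stronger inhibitor, a higher number a weaker inhibitor), compound 1 gives 43000 nM.
Compound 2 `CCOC(=O)c1c(C)oc2ncnc(Nc3cccc(Br)c3)c12`: compound 2 reaches only the limit of this assay, > 1000000 nM.
Compound 3 `Cc1oc2ncnc(Nc3cccc(Cl)c3)c2c1C(=O)O`: compound 3 gives 95500 nM.

Two changes are covered. The first, (ethyl in place of hydrogen on an oxygen next to a carbonyl group), gives an at least 23-fold higher number from compound 1 to compound 2 (1.36 log units; beyond the scatter); the size is bounded only from below because compound 2 sits at the limit of > 1000000 nM in this assay, at which 1 of the 3 values shown sits. The second, (chloro in place of bromo on an aromatic carbon), gives a 2.2-fold higher number from compound 1 to compound 3 (0.35 log units; beyond the scatter), so the two acids differ by a modest step, with compound 3 standing highest of the two numbered acids.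

Compound 4 `CCOC(=O)c1c(C)oc2ncnc(Nc3cccc(Cl)c3)c12` has not been measured. It differs from compound 3 by ethyl in place of hydrogen on an oxygen next to a carbonyl group, and the same change has been made from compound 1 to compound 2: the place lines of the two pairs read the same word for word, so this is the same change on a core that differs only by the chloro in place of bromo already described. Within the data shown here, with only one measured example of the ester step, and that example bounded only from below, the expectation rests on compound 1 to compound 2 alone, an at least 23-fold higher number from compound 1 to compound 2 (1.36 log units; beyond the scatter), combined with the higher starting number of compound 3, 95500 nM. Compound 4 is therefore expected to lose activity by about a 21-fold higher number from compound 3 to compound 4 (1.32 log units; beyond the scatter). The estimate for compound 4 in this assay is 2000000 nM, spanning 300000 nM to 10000000 nM, with a high chance that only a limit is reported.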

Compound 4, half-maximal inhibitory concentration: > 1000000 nM
Compound 4: a limit, no number; the forecaster's own chance of this, stated with the estimate: 75%; the middle value does not contradict the limit.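

In this assay the change from carboxy to ethoxycarbonyl acts in the same direction on the chloro acid as on the bromo acid, with an at least 10-fold higher number from compound 3 to compound 4 (1.01 log units; beyond the scatter), so the direction of the step carries over between these two cores: the same change on two cores in this assay, an at least 23-fold higher number (1.36 log units; beyond the scatter) from compound 1 to compound 2 and an at least 10-fold higher number (1.01 log units; beyond the scatter) from compound 3 to compound 4; the limit leaves it open whether they differ

The size of the step does not carry over in any readable way, since both ethyl esters end at the same limit and not at a number: the limit of > 1000000 nM in this assay, at which 2 of the 4 values shown sit.

The step from compound 2 to compound 4 cannot be read, so the gap seen between the acids, a 2.2-fold higher number from compound 1 to compound 3 (0.35 log units; beyond the scatter), cannot be checked on the esters, and nothing shows whether chloro and bromo differ once the ethoxycarbonyl group is in place.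

The compounds shown leave open whether a methyl ester, a longer chain on the same oxygen or a primary amide in place of the carboxy group would give a number short of the limit, which is what a comparison of step sizes would need. Also open, from the compounds shown here alone, is how fluoro, iodo or methyl in place of the bromo would stand against the two acids, as the halogen comparison rests on a single pair.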